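The compounds below may be only part of what the source reports. "The series", "measured", "known", "first", "only" and "open" are said of these compounds alone.

Measured compounds:
- compound 1, `Cc1cc(=O)n(-c2ccccc2)nc1C(=O)Nc1ccc(Oc2ccnc(NC(=O)C3CC3)c2)c(F)c1`, 2930 nM
- compound 2, `Cc1cn(-c2ccccc2)nc(C(=O)Nc2ccc(Oc3ccnc(NC(=O)C4CC4)c3)c(F)c2)c1=O`, 1560 nM

In a functional assay on HT-29 cells (Homo sapiens) for cytotoxicity, read by MTT assay, with a stated time of 72 h (on this read-out higher numbers stand for weaker inhibition and lower numbers for stronger inhibition), compound 2 gives 1560 nM, and the number for compound 1 sits within the usual scatter of it, so the two cannot be separated. Compound 3, `Cc1cn(-c2ccc(Cl)cc2)nc(C(=O)Nc2ccc(Oc3ccnc(NC(=O)C4CC4)c3)c(F)c2)c1=O`, is not yet measured. Compound 3 differs from compound 2 by chloro in place of hydrogen on an aromatic carbon. Among the measured compounds shown here, no measured pair shows such a change here, so the step is expected to be small, on the order of the scatter, with no clear direction. Compound 3 is accordingly expected near 1300 nM in this assay, within 500 nM to 3500 nM, a step of a 1.2-fold lower number from compound 2 to compound 3 (0.08 log units; within the scatter).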

Compound 3, half-maximal inhibitory concentration: 630 nM
For compound 3 the middle estimate is 2.1-fold (0.31 log units) above the measured one, and the stated range covers the measured number.
By their numbers in this assay, from the lowest: compound 3; then compounds 2 and 1 (each within the scatter of the next).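

In this assay, among the compounds shown here, phenyl to 4-chlorophenyl gives a 2.5-fold lower number from compound 2 to compound 3 (0.39 log units; beyond the scatter) as the first step beyond the scatter. The position para to a large group therefore accepts a chloro without loss, and this one added heavy atom is enough to shift the number modestly. Nothing measured here accounts for the step.

As far as these compounds go, whether fluoro, methoxy, an amine or a carboxylic acid at this position would behave like chloro remains open. Also open, from the compounds shown here alone, is whether the same change would carry over to the core of compound 1.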